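The source may hold more compounds than are shown below. What is called first, only, known or untested is meant among the compounds shown, and "the series" means these compounds.

Measured so far:
compound 1 `CCc1cc(Nc2nc(N[C@@H](C)c3cccc(F)c3)nc3ccccc23)n[nH]1` — 340 nM
compound 2 `CCc1cc(Nc2nc(N[C@@H](C)c3ncc(F)cn3)nc3cccc(F)c23)n[nH]1` — 230 nM
compound 3 `CCc1cc(Nc2nc(NCc3ccc(Cl)cc3)nc3cccc(OC)c23)n[nH]1` — 16 nM

All three were run in an assay on isolated protein for inhibition of G protein-coupled receptor kinase 6 (Homo sapiens), read by scintillation counting, radiometric assay and 33P incorporation, with a stated time of 80 min, in the presence of a further agent that is not named here; a higher number here means a weaker inhibitor, a lower number a stronger inhibitor. Compound 1 has the highest number of the three, but the gap to compound 2 lies within the usual scatter, so the two are not separated; only compound 3 stands apart, its number beyond the scatter from compound 1. Compound 3 differs from compound 1 in more than one place, so no single step can be read from that pair.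

The next compound is compound 4 `CCc1cc(Nc2nc(N[C@@H](C)c3ccc(Cl)cc3)nc3ccccc23)n[nH]1`, which differs from compound 1 in one place: 4-chlorophenyl in place of 3-fluorophenyl on a saturated chain carbon bound to a nitrogen on an aromatic ring and a saturated chain carbon. Going by the values given here, no measured pair isolates this change. Among the compounds with values here, the only pointer is compound 3, which also carries a 4-chlorophenyl yet differs elsewhere, and which in this assay gives 16 nM. The expectation is therefore a modest move to a lower number, possibly not beyond the scatter, and the estimated step is a 2.1-fold lower number from compound 1 to compound 4 (0.33 log units; beyond the scatter). Compound 4 is expected at 160 nM, with a range of 50 nM to 500 nM.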

Compound 4, half-maximal inhibitory concentration: 70 nM
Compound 4: the middle estimate sits 2.3-fold (0.36 log units) above what was measured; measured number inside the range.
By their numbers in this assay, from the lowest: compound 3; then compound 4; then compounds 2 and 1 (each within the scatter of the next).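

In this assay this position proves sensitive to the aryl group: 4-chlorophenyl in place of 3-fluorophenyl, on a saturated chain carbon bound to a nitrogen on an aromatic ring and a saturated chain carbon, gives the only single-place step shown (a 4.9-fold lower number from compound 1 to compound 4 (0.69 log units; beyond the scatter)). The step is read on an otherwise unchanged structure, so it can be assigned to this swap alone. The heavy-atom count and the hydrogen-bond donor and acceptor counts stay the same across it, so those counts do not distinguish the two groups, and no measurement shown bears on the reason for the shift.

The swap changes both the halogen and its ring position, so the pair cannot say which of the two carries the step. 3-chlorophenyl and 4-fluorophenyl would separate them, and a 4-aminomethylphenyl would test whether an amine is tolerated here.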